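Methyl stereocentre in the series: solubility notes

A few compounds are considered here, and "the series" means these few. Any claim that something is new, unique, unknown or untested is made for them only; others in the source may bear on it.

Values in a physicochemical assay for solubility, measured as kinetic solubility, with a stated time of 1 h, at pH 7.4; a lower number here means a less soluble compound, a higher number a more soluble compound:
- compound 1 `CC(=O)NC1=NN(c2ccc(Cl)c(Cl)c2)CC1`: 31000 nM
- compound 2 `CC(=O)NC1=NN(c2ccc(Cl)c(Cl)c2)[C@H](C)C1`: 173000 nM

Of the two numbers in this assay, compound 2 holds the higher, at 173000 nM. The next compound to examine is compound 3 `CC(=O)NC1=NN(c2ccc(Cl)c(Cl)c2)[C@@H](C)C1`. Relative to compound 2, the change is the two compounds have the same atoms and bonds and differ only in configuration as drawn: 1 of 1 stereo elements differ; a stereocentre at a saturated ring carbon is drawn R in compound 2 and S in compound 3. Within the data shown here, only one measured step bears on this, and only indirectly: a 5.6-fold higher number from compound 1 to compound 2 (0.75 log units; beyond the scatter). That step introduced the methyl in place of hydrogen on a saturated ring carbon. Among the measured compounds shown here, compound 3 keeps that methyl, and no measured pair yet compares the two configurations. With no measured effect of configuration to draw on, no change beyond the scatter is expected in this assay. The expected step, a 1.0-fold lower number from compound 2 to compound 3 (0.02 log units; within the scatter), is correspondingly small. For compound 3 the estimated value is 165000 nM, with an expected range of 85000 nM to 310000 nM.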

Compound 3, solubility: 125000 nM
For compound 3 the middle estimate is 1.3-fold (0.12 log units) above the measured one; low and high end bracket the measured number.
By their numbers in this assay, from the lowest: compound 1; then compounds 3 and 2 (each within the scatter of the next).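

In this assay the change of configuration gives a 1.4-fold lower number from compound 2 to compound 3 (0.14 log units; within the scatter), so the two configurations at this saturated ring carbon cannot be told apart on this read-out. Methyl in place of hydrogen now has a second reading, a 4.0-fold higher number from compound 1 to compound 3 (0.61 log units; beyond the scatter), alongside a 5.6-fold higher number from compound 1 to compound 2 (0.75 log units; beyond the scatter), and because both lie beyond the scatter, the rise over compound 1 is not tied to one configuration as drawn. This pair isolates configuration and nothing else: the fact that compounds 2 and 3 differ only in the configuration as drawn.

Open, from the compounds shown here alone, is whether an ethyl or a hydroxymethyl group on this ring carbon would give a step of similar size from compound 1. Also open, going by these compounds, is whether the two configurations would still stay within the scatter of each other with such a larger group in place of the methyl.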